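From tert-butoxycarbonyl to isopropoxycarbonyl at a limit

The compounds below may be only part of what the source reports. "The series", "measured", "known", "first", "only" and "open" are said of these compounds alone.

Compound 1 `Cc1cc(NC(=O)C2CCCC2)nn1Cc1cc(Cl)ccc1OCC(C)C` carries cyclopentyl on a carbonyl carbon, and compound 2 `Cc1cc(NC(=O)OC(C)(C)C)nn1Cc1cc(Cl)ccc1OCC(C)C` carries tert-butoxy in that place. In a physicochemical assay for lipophilicity, at pH 7.4 (on this read-out lower numbers stand for lower lipophilicity and higher numbers for higher lipophilicity), compound 1 gives > 3.7, which is a limit and not a number. In this assay compound 2 gives > 3.7, which is likewise a limit. Compound 2 therefore stands only at a limit, and the evidence is the same for both compounds: the limit of > 3.7 in this assay, at which 2 of the 2 values shown sit.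

Compound 3 `Cc1cc(NC(=O)OC(C)C)nn1Cc1cc(Cl)ccc1OCC(C)C` differs from compound 2 at a single place: hydrogen in place of methyl on a saturated chain carbon bound to an oxygen next to a carbonyl group and two saturated chain carbons. In the words of the group, tert-butoxy gives way to isopropoxy. For the measured compounds named here, the only measured step that bears on this change is a step that the two limits leave unreadable from compound 1 to compound 2, and it offers no size to carry over. The expectation therefore rests on the small structural change and on the limit of compound 2, and it is a modest downward step. The expected change is a step that the limit leaves unreadable from compound 2 to compound 3. A further limit in this assay is expected to be the more likely report. For compound 3 the estimate is 3.8, with an expected range from 3.4 to 4.3.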

Compound 3, distribution coefficient: > 3.7
Compound 3 gave a limit, no number; the forecaster's own chance of this, stated with the estimate: 65%; the middle value does not contradict the limit.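

In this assay compound 3 gives > 3.7, which is a limit and not a number. No step among compound 1, compound 2 and compound 3 can be read: the limit of > 3.7 in this assay, at which 3 of the 3 values shown sit.

The compounds shown leave open the actual number for each of the three, and so whether cyclopentyl, tert-butoxy and isopropoxy differ at all on this read-out.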